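The compounds below may be only part of what the source reports. "The series", "measured", "known", "first", "only" and "open" are said of these compounds alone.

Compound 1 `N#Cc1cc2c(nc1N1CCC(F)(C(=O)NS(=O)(=O)Cc3ccc(Cl)cc3)CC1)COC2=O`: 37200 nM
Compound 2 `Cc1ccc(CS(=O)(=O)NC(=O)C2(F)CCN(c3nc4c(cc3C#N)C(=O)OC4)CC2)cc1`: 32800 nM
Compound 3 `CC1(C(=O)NS(=O)(=O)Cc2ccccc2)CCN(c2nc3c(cc2C#N)C(=O)OC3)CC1`: 6680 nM

In a functional assay (Platelet, plasma) for inhibition, with Homo sapiens as the target (on this read-out higher numbers stand for weaker inhibition and lower numbers for stronger inhibition), compound 3 gives 6680 nM, the lowest number of the three, which makes it the strongest inhibitor so far. Compound 1 and compound 2 both lie clearly higher.

The next compound, compound 4 `N#Cc1cc2c(nc1N1CCC(F)(C(=O)NS(=O)(=O)Cc3ccccc3)CC1)COC2=O`, differs from compound 3 in one place: fluoro in place of methyl on a saturated ring carbon. In words, this is fluoro in place of methyl on a saturated ring carbon.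

Within the data shown here, no measured pair isolates this swap. Among the measured compounds shown here, the only measured step, a 1.1-fold lower number from compound 1 to compound 2 (0.05 log units; within the scatter), is methyl in place of chloro on an aromatic carbon, so it bears on the swap only indirectly. It does suggest that the choice between those two groups matters little here.

Compound 1 and compound 2 carry the fluoro of compound 4, but they also carry an extra group on an aromatic carbon that compound 3 lacks. Their higher values therefore cannot be assigned to either difference alone. If the fluoro accounts for part of that gap, a moderate rise would follow, and the expected change is a 2.2-fold higher number from compound 3 to compound 4 (0.35 log units; beyond the scatter). For compound 4 the estimated value is 15000 nM, with an expected range from 6000 nM to 38000 nM.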

Compound 4, half-maximal inhibitory concentration: 1210 nM
Estimate against measurement, compound 4: 12-fold (1.09 log units) above, outside the stated range (below it).
By their numbers in this assay, from the lowest: compound 4; then compound 3; then compounds 2 and 1 (each within the scatter of the next).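

In this assay, fluoro in place of methyl on the saturated ring carbon gives a 5.5-fold lower number from compound 3 to compound 4 (0.74 log units; beyond the scatter) and so stronger inhibition, which shows that at this position, three ring bonds from the ring nitrogen, fluoro is the better of the two groups when the aromatic ring carries no further group. With that fluoro held constant, the aromatic carbon proves far more sensitive, since hydrogen in place of methyl gives a 27-fold lower number from compound 2 to compound 4 (1.43 log units; beyond the scatter) and hydrogen in place of chloro gives a 31-fold lower number from compound 1 to compound 4 (1.49 log units; beyond the scatter) in the same direction (both steps large). Among these compounds, the high numbers of compound 1 and compound 2 therefore go with the extra aromatic group and not with the fluoro, a separation that the earlier compounds could not make.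

Nothing available here explains why either change shifts the inhibition. From the compounds shown here alone, it remains open how plain hydrogen or a hydroxyl on the saturated ring carbon would compare with fluoro, and whether a smaller aromatic group such as fluoro or a different one such as methoxy would also raise the number as methyl and chloro do.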